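The compounds below may be only part of what the source reports. "The series", "measured", "known", "first", "only" and "open" are said of these compounds alone.

Working notes on the series built on the shared core of compound 1 `CC(C)[C@H]1CC[C@@]2(CO2)[C@H]2C(=O)OCC(C(=O)O)=C[C@H]12`. In a functional assay on NAMALVA cells (Homo sapiens) for inhibition, with a stated time of 72 h (a lower number here means a stronger inhibitor, a higher number a weaker inhibitor), compound 1 gives 302 nM, the lowest of the two numbers in hand. Its nearest neighbour is compound 3 `CC(C)[C@H]1CC[C@@](O)(CI)[C@H]2C(=O)OCC(C(=O)O)=C[C@H]12`, which in this assay gives 3260 nM. Compound 2 `CC(C)[C@H]1CC[C@@](O)(CO)[C@H]2C(=O)OCC(C(=O)O)=C[C@H]12` reaches only a limit, (the limit of > 32000 nM in this assay, at which 1 of the 3 values shown sits), namely > 32000 nM. Within the data shown here, the single step measured so far, an at least 9.8-fold lower number from compound 2 to compound 3 (0.99 log units; beyond the scatter), concerns the saturated chain carbon and not the carboxy end. Compound 4 `COC(=O)C1=C[C@@H]2[C@@H](C(C)C)CC[C@@]3(CO3)[C@H]2C(=O)OC1` differs from compound 1 by methyl in place of hydrogen on an oxygen next to a carbonyl group. Among the measured compounds shown here, no measured step touches that oxygen, so nothing points to a shift beyond the scatter in either direction. Compound 4 is therefore estimated at 350 nM, with a range from 60 nM to 3000 nM kept wide for lack of precedent. The expected step is a 1.2-fold higher number from compound 1 to compound 4 (0.06 log units; within the scatter).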

Compound 4, half-maximal inhibitory concentration: 1740 nM
Compound 4: middle estimate off by 5.0-fold (0.70 log units), on the low side, and the stated range covers the measured number.
By their numbers in this assay, from the lowest: compound 1; then compounds 4 and 3 (each within the scatter of the next). At a limit, above all of these: compound 2.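

In this assay the carboxy end now has a measured step: a 5.8-fold higher number from compound 1 to compound 4 (0.76 log units; beyond the scatter) shows that methyl in place of hydrogen on this oxygen is not a neutral change. The hydrogen is not indispensable, however, as compound 4 still gives 1740 nM in this assay. Nothing in hand accounts for the size of this shift.

Open, on these data alone, is whether ethoxycarbonyl or a primary amide at this carbonyl would read closer to compound 1 or to compound 4. Also open, as far as these compounds go, is whether carboxy to methoxycarbonyl has a similar effect on compound 3.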